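The compounds below may be only part of what the source reports. "The series", "measured", "known", "first", "only" and "open" are said of these compounds alone.

Measured compounds and their values:

Compound 1 `O=C1COc2ccc(-c3cccc(NS(=O)(=O)c4ccc(F)cc4)c3)cc2N1c1ccccc1`: in a functional assay on A-375 cells (Homo sapiens) for antiproliferative activity, read by MTT assay, with a stated time of 72 h (on this read-out higher numbers stand for weaker inhibition and lower numbers for stronger inhibition), compound 1 gives > 40000 nM, a limit of the assay rather than a number.
Compound 2 `COc1ncc(-c2ccc3c(c2)N(c2ccc(F)cc2)C(=O)CO3)cc1NS(=O)(=O)c1ccc(F)cc1`: in this assay compound 2 gives > 40000 nM, likewise a limit.
Compound 3 `O=C1COc2ccc(-c3cnc(Cl)c(NS(=O)(=O)c4ccc(F)cc4)c3)cc2N1C1CCCCC1`: in this assay compound 3 gives > 40000 nM, again a limit.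

All three measured compounds share a core and a sulfonamide arm, and none of them reached a measurable half-maximal inhibitory concentration in this assay. Compound 1 therefore stands at the upper edge of what the assay can report, together with the two others: the limit of > 40000 nM in this assay, at which 3 of the 3 values shown sit. Among the compounds with values here, there is no measured pair of compounds that differ in one place, so no step size can be read from the data.

Compound 4 `O=C1COc2ccc(-c3cccc(NS(=O)(=O)c4ccc(F)cc4)c3)cc2N1c1ccc(Cl)cc1` is the unmeasured member of the set. Its change from compound 1 is chloro in place of hydrogen on an aromatic carbon. With every measured compound sitting at the limit, the expectation for this step is none beyond the scatter, and the most probable outcome is that compound 4 again returns only a limit. The estimate for compound 4 is 60000 nM, with a range from 20000 nM to 200000 nM, which means an expected step that the limit leaves unreadable from compound 1 to compound 4.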

Compound 4, half-maximal inhibitory concentration: 32500 nM
Compound 4: the middle estimate sits 1.8-fold (0.27 log units) above what was measured; the measured number falls inside the stated range.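

In this assay, compound 4 gives 32500 nM, the only value among the compounds shown that is a true number and not a limit, so a reading within the assay's range is possible with chloro at this place, para to a large group. Compound 1 gives > 40000 nM, which is a limit of the assay. The change from phenyl to 4-chlorophenyl comes with an at least 1.2-fold lower number from compound 1 to compound 4 (0.09 log units; that floor lies within the scatter), and it remains unknown whether chloro makes any real difference, because the starting value is not a number: the limit of > 40000 nM in this assay, at which 3 of the 4 values shown sit.

The compounds shown leave open how a different group at this same place, such as bromo, an amine or a carboxylic acid, would read in this assay, and whether any such group could bring the value well clear of the limit. They also leave open whether chloro at this place would give a measurable value on the otherwise different structures of compound 2 and compound 3.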